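The source may hold more compounds than are shown below. What is called first, only, known or untested is meant among the compounds shown, and "the series" means these compounds.

Measured so far in a functional assay on RPMI18226 cells (Homo sapiens) for antiproliferative activity, read by sulforhodamine B assay, with a stated time of 48 h, tested at 10 uM; on this read-out lower numbers stand for less inhibition and higher numbers for more inhibition at the one concentration tested (going by the name of the read-out):
Compound 1 `O=C(Nc1ccccc1)c1c(-c2ccc(Cl)cc2)cc(-c2ccccc2)nc1N1CCCCC1` gives 13%.
Compound 2 `Nc1nc(-c2ccccc2)cc(-c2ccc(Cl)cc2)c1C(=O)Nc1ccccc1` gives 46%.
Compound 3 `Cc1ccc(NC(=O)c2c(-c3ccc(Cl)cc3)cc(-c3ccccc3)nc2N)cc1` gives 71%.

Compound 2 stands second highest of the three numbers. Its nearest neighbour is compound 3, which lies a number 25 percentage points higher from compound 2 to compound 3 (beyond the scatter), a change that follows the methyl in place of hydrogen on an aromatic carbon. Furthest from it is compound 1; the move a number 33 percentage points higher from compound 1 to compound 2 (beyond the scatter) came with amino in place of piperidin-1-yl on an aromatic carbon.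

The next compound, compound 4 `O=C(Nc1ccccc1)c1c(-c2ccc(Cl)cc2)cc(-c2ccccc2)nc1Nc1ccccc1`, is still to be measured in this assay. It differs from compound 2 in one place: phenyl in place of hydrogen on a nitrogen on an aromatic ring. Within the data shown here, of the two measured steps, only the one from compound 1 to compound 2 touches the same nitrogen, and there the substituted amine stood well below the free amino group. The step to compound 3 concerns a different part of the molecule and says little about this change. Among the measured compounds shown here, the expectation therefore is a step downward in this assay for compound 4, estimated as a number 21 percentage points lower from compound 2 to compound 4 (beyond the scatter), though with a generous spread since only one comparable step is at hand. Compound 4 is expected to give about 25%, within a range from 5% to 50%.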

Compound 4, a percentage reported as inhibition, at one concentration (the size of the read-out at that concentration, not a potency): 15%
Estimate against measurement, compound 4: 10 percentage points above, within the range that was stated.
By their numbers in this assay, from the lowest: compounds 1 and 4 (each within the scatter of the next); then compound 2; then compound 3.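

In this assay, the change from amino to anilino, with phenyl in place of hydrogen on a nitrogen on an aromatic ring, gives a number 31 percentage points lower from compound 2 to compound 4 (beyond the scatter). Until now, the only substituted nitrogen at this position was the piperidin-1-yl of compound 1, so the low reading could have belonged to that saturated ring alone; compound 4 shows that an aromatic ring on this nitrogen also goes with a reading well under that of the free amino group in compound 2, and the step between the two substituted forms, a number 2 percentage points higher from compound 1 to compound 4 (within the scatter), does not separate them. Among these compounds, the free amino group is thus the only form at this position that stands clear of the low level, but no measurement here accounts for the drop.

The compounds shown leave open whether a group much smaller than phenyl on this nitrogen, such as methyl or ethyl, would keep the reading of compound 2 or fall to the level of compound 4. They also leave open whether methyl in place of hydrogen, the change that separates compound 3 from compound 2, would raise the reading in the anilino series as well.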